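Changing the aryl group on the hydrazone carbon of compound 3

A few compounds are considered here, and "the series" means these few. Any claim that something is new, unique, unknown or untested is made for them only; others in the source may bear on it.

Of the compounds shown here, three have been measured in a functional assay on NCI-H460 cells (Homo sapiens) for cytotoxicity, read by MTT assay, with a stated time of 72 h; a lower number here means a stronger inhibitor, a higher number a weaker inhibitor. Compound 1 `CN(C)CCn1cnnc1-c1cc(Oc2ccc(NC(=O)N/N=C/c3ccc(Cl)cc3)cc2F)ccn1` gives 320 nM, compound 2 `CN(C)CCn1cnnc1-c1cc(Oc2ccc(NC(=O)N/N=C/c3cccc(Cl)c3Cl)cc2F)ccn1` gives 72 nM, and compound 3 `CN(C)CCn1cnnc1-c1cc(Oc2ccc(NC(=O)N/N=C/c3c(Cl)cccc3Cl)cc2F)ccn1` gives 350 nM. Compound 3 has the highest number of the three, but its gap to compound 1 is within the scatter, so the two cannot be told apart; only compound 2 stands clearly apart, with a 4.9-fold higher number from compound 2 to compound 3 (0.69 log units; beyond the scatter).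

Compound 4 `COc1cc(/C=N/NC(=O)Nc2ccc(Oc3ccnc(-c4nncn4CCN(C)C)c3)c(F)c2)ccc1O` differs from compound 3 in one place: 4-hydroxy-3-methoxyphenyl in place of 2,6-dichlorophenyl on a carbon with a double bond to nitrogen. For the measured compounds named here, no measured step swaps chlorine for oxygen-bearing groups, so none bears on this change directly. What the measured steps do show is how much the number moves when the aryl group on the carbon with a double bond to nitrogen is altered: a 4.4-fold lower number from compound 1 to compound 2 (0.65 log units; beyond the scatter), a 4.9-fold higher number from compound 2 to compound 3 (0.69 log units; beyond the scatter), and a 1.1-fold higher number from compound 1 to compound 3 (0.04 log units; within the scatter). Changes there have thus ranged from no effect to a modest one.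

Going by the values given here, with no direct precedent, the expected step of a 1.1-fold higher number from compound 3 to compound 4 (0.06 log units; within the scatter) is none beyond the scatter, with a wide range. Compound 4 is therefore estimated at 400 nM, between 90 nM and 2000 nM.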

Compound 4, half-maximal inhibitory concentration: 57 nM
For compound 4 the middle estimate is 7.0-fold (0.85 log units) above the measured one; measured number outside the range, below it.
By their numbers in this assay, from the lowest: compounds 4 and 2 (each within the scatter of the next); then compounds 1 and 3 (each within the scatter of the next).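

Up to now every aryl group on the carbon with a double bond to nitrogen carried chlorine, so the measured range said nothing about a ring without it. In this assay there is a 6.1-fold lower number from compound 3 to compound 4 (0.79 log units; beyond the scatter) and also a 5.6-fold lower number from compound 1 to compound 4 (0.75 log units; beyond the scatter) so 4-hydroxy-3-methoxyphenyl, which holds no chlorine and brings oxygen atoms and a hydrogen-bond donor to this position, reaches the lower of the two levels seen so far. That level had been held only by compound 2, yet a 1.3-fold lower number from compound 2 to compound 4 (0.10 log units; within the scatter) leaves the 2,3-dichlorophenyl and 4-hydroxy-3-methoxyphenyl groups indistinguishable, so chlorine is not needed for a low number here, and no measurement on hand explains why these aryl groups fall into two levels.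

The hydroxy and methoxy groups enter together, so the compounds shown leave open whether the step from compound 3 to compound 4 rests on one of them, on both, or simply on the loss of the 2,6-dichlorophenyl group. A ring bearing only a hydroxy group or only a methoxy group would separate these readings, and a ring bearing an amine or a carboxylic acid would test how far this position tolerates other groups.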